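Extending the ring-bound methyl with a hydroxyl group

A few compounds are considered here, and "the series" means these few. Any claim that something is new, unique, unknown or untested is made for them only; others in the source may bear on it.

Among the compounds with values here, compound 1 `Cc1cnc(NC(=O)c2cc(Oc3ccc(S(C)(=O)=O)cc3)c3cn(C)nc3c2)cn1` is the more soluble of the two compounds measured so far. In a physicochemical assay for solubility, measured as kinetic solubility (a higher number here means a more soluble compound, a lower number a less soluble compound), compound 1 gives 454000 nM, the higher of the two numbers. Its closest neighbour is compound 2 `CCS(=O)(=O)c1ccc(Oc2cc(C(=O)Nc3cnc(C)cn3)cc3nn(C)cc23)cc1`, which in this assay gives 69000 nM. Within the data shown here, the only measured step, a 6.6-fold lower number from compound 1 to compound 2 (0.82 log units; beyond the scatter), comes from a methyl in place of hydrogen on a saturated chain carbon bound to a sulfonyl sulfur, a change at the other end of the molecule.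

Compound 3 `Cc1cnc(NC(=O)c2cc(Oc3ccc(S(C)(=O)=O)cc3)c3cn(CCO)nc3c2)cn1` differs from compound 1 in one place: hydroxymethyl in place of hydrogen on a saturated chain carbon bound to an aromatic nitrogen. Cut one bond further out, the same difference reads as methyl to 2-hydroxyethyl on the ring nitrogen. Among the measured compounds shown here, no measured step touches this position or this kind of group, so the step from compound 1 to compound 2 gives no direct guide, and the expectation rests on the change alone. The estimated step of a 1.2-fold higher number from compound 1 to compound 3 (0.08 log units; within the scatter) is therefore expected to stay close to the scatter. For compound 3 the estimate in this assay is 550000 nM, within a range from 230000 nM to 1300000 nM.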

Compound 3, solubility: 24400 nM
Estimate against measurement, compound 3: 23-fold (1.35 log units) above; measured number below the stated range.
By their numbers in this assay, from the lowest: compound 3; then compound 2; then compound 1.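

The aromatic nitrogen carrying the methyl group in compound 1 turns out to be a sensitive place in this assay: replacing that methyl with 2-hydroxyethyl gives a 19-fold lower number from compound 1 to compound 3 (1.27 log units; beyond the scatter) and takes the read-out well beyond the scatter. Within the data shown here, until now, the only measured change was at the sulfonyl end of the molecule, where the step was a 6.6-fold lower number from compound 1 to compound 2 (0.82 log units; beyond the scatter) and so gave no information about this nitrogen; the two steps now show that changes at both places move the number, and in both cases it goes down from compound 1. No measurement shown here explains why the hydroxymethyl addition has this outcome.

The compounds shown leave open whether the drop follows the added chain carbon or the added hydroxyl, a question that an ethyl group on the same nitrogen could help to separate from the 2-hydroxyethyl result. They also leave open how a 2-methoxyethyl group, a 2-aminoethyl group or a carboxylic acid on a chain at this nitrogen would compare with the methyl of compound 1.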